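A few compounds are considered here, and "the series" means these few. Any claim that something is new, unique, unknown or untested is made for them only; others in the source may bear on it.

In an ADME assay on Caco-2 cells (Homo sapiens) for permeability; a lower number here means that the compound crosses the layer more slowly, a higher number that the compound crosses the layer faster:
- compound 1 `Cc1ccc(NC(=O)CCc2nnc(CCCC(C)C)n2C2CC2)c(C)c1`: 36 10^-6 cm/s
- compound 2 `CC(=O)NCCC(CC(=O)Nc1ccc(C)cc1C)c1nnc(CCCC(C)C)n1C1CC1`: 1.3 10^-6 cm/s

Compound 2 holds the lower of the two numbers, and the gap to compound 1 lies beyond the scatter. Compound 3 `CNC(=O)CCC(CC(=O)Nc1ccc(C)cc1C)c1nnc(CCCC(C)C)n1C1CC1` differs from compound 2 as follows: methylcarbamoyl in place of acetamido on a saturated chain carbon, three bonds along the chain from an aromatic carbon. The two have the same atoms, joined differently.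

Going by the values given here, only one measured step bears on this change: a 28-fold lower number from compound 1 to compound 2 (1.44 log units; beyond the scatter). That large step replaced hydrogen with 2-acetamidoethyl, whereas compound 3 keeps a side chain of the same atoms as 2-(methylcarbamoyl)ethyl. Among the compounds with values here, no measured step covers the swap itself, so the large step gives no direct size for it. A repeat of that size is not expected in this assay, and no direction is favoured. The expected change is a 1.2-fold higher number from compound 2 to compound 3 (0.06 log units; within the scatter), which would stay within the scatter. For compound 3 the estimated value is 1.5 10^-6 cm/s, with an expected range of 0.6 10^-6 cm/s to 4 10^-6 cm/s.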

Compound 3, apparent permeability: 1.5 10^-6 cm/s
Compound 3: the middle estimate sits on the measured number at the digits printed; the range from low to high includes it.
By their numbers in this assay, from the lowest: compounds 2 and 3 (each within the scatter of the next); then compound 1.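

In this assay, methylcarbamoyl in place of acetamido gives a 1.2-fold higher number from compound 2 to compound 3 (0.06 log units; within the scatter), so at this position the two arrangements of the same atoms cannot be told apart. The large step from the unsubstituted chain now appears with a second side chain: 2-(methylcarbamoyl)ethyl in place of hydrogen gives a 24-fold lower number from compound 1 to compound 3 (1.38 log units; beyond the scatter), which shows that the low numbers are not confined to the acetamido arrangement. No measured evidence is available to explain either step.

Still open, going by these compounds, is whether the low numbers depend on the amide in the side chain or follow from any substituent on this carbon. A plain ethyl, a 2-aminoethyl or a 2-carboxyethyl group in the same place would help to separate these two readings.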